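From a primary amide to a 2-aminophenyl amide

The source may hold more compounds than are shown below. What is called first, only, known or untested is meant among the compounds shown, and "the series" means these compounds.

In a functional assay on blood (Homo sapiens), with a stated time of 60 min, in the presence of a further agent that is not named here (a lower number here means that less compound is needed, a higher number that more compound is needed for the effect), compound 1 (`O=S(=O)(c1ccc(Oc2ccc(OC(F)(F)F)cc2)cc1)C1CCC2(CCNCC2)C1`) gives > 15000 nM as a limit of the assay, not a number. Compound 2 (`O=C(OCc1ccccc1)C1(S(=O)(=O)c2ccc(Oc3ccc(OC(F)(F)F)cc3)cc2)CCC2(CCNCC2)C1`) gives > 15000 nM as a limit too. Compound 3 (`NC(=O)C1(S(=O)(=O)c2ccc(Oc3ccc(OC(F)(F)F)cc3)cc2)CCC2(CCNCC2)C1`) gives 3700 nM and is the only one of the three with an actual number. Carbamoyl in place of hydrogen on a saturated ring carbon gives an at least 4.0-fold lower number from compound 1 to compound 3 (0.60 log units; beyond the scatter) and shows that this group matters.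

Compound 4 (`Nc1ccccc1NC(=O)C1(S(=O)(=O)c2ccc(Oc3ccc(OC(F)(F)F)cc3)cc2)CCC2(CCNCC2)C1`) carries 2-aminophenyl in place of hydrogen on an amide-type nitrogen and is otherwise the same as compound 3. The nearest guide is amino in place of benzyloxy on a carbonyl carbon, which gives an at least 4.0-fold lower number from compound 2 to compound 3 (0.60 log units; beyond the scatter) and suggests that an aromatic ring attached through that carbonyl may not be welcome. A higher number is therefore expected in this assay with an estimated 2.2-fold higher number from compound 3 to compound 4 (0.33 log units; beyond the scatter) as the step. For compound 4 the expected value is 8000 nM with an estimated range from 2000 nM to 30000 nM and the assay may well report only a limit.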

Compound 4, half-maximal effective concentration: 900 nM
Beside the measured number, compound 4's estimate is 8.9-fold (0.95 log units) above it; measured number below the stated range.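

Putting 2-aminophenyl on the amide-type nitrogen gives a 4.1-fold lower number from compound 3 to compound 4 (0.61 log units; beyond the scatter) in this assay and shows that this nitrogen accepts an aromatic ring, which compound 3 alone could not reveal. On the same carbonyl carbon, (2-aminophenyl)amino in place of benzyloxy gives an at least 16-fold lower number from compound 2 to compound 4 (1.22 log units; beyond the scatter) and shows that a ring attached through that carbonyl is not unwelcome in every form, while (2-aminophenyl)carbamoyl on the saturated ring carbon gives an at least 16-fold lower number from compound 1 to compound 4 (1.22 log units; beyond the scatter) from the core without any such group. Both of these last steps are minimum sizes because they start from a limit of the assay: the limit of > 15000 nM in this assay, at which 2 of the 4 values shown sit.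

The compounds shown leave open whether the ring alone accounts for the gain or its amino group takes part; a plain phenyl or a 2-hydroxyphenyl on that nitrogen would separate the two. Also open, on these data alone, is how a pyridine ring would fare there.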